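Compound 3 to compound 4: a chloro step

The compounds below may be only part of what the source reports. "The series", "measured", "known", "first", "only" and "open" are said of these compounds alone.

Compound 1 `O=c1cnn(-c2ccc(Sc3ccc(Cl)cc3)c(Cl)c2)c(=O)[nH]1`: 38 h
Compound 2 `O=c1cnn(-c2cc(Cl)c(Sc3ccc(Cl)cc3)c(Cl)c2)c(=O)[nH]1`: 47 h
Compound 3 `Cc1cc(-n2ncc(=O)[nH]c2=O)ccc1S(=O)(=O)c1ccc(Cl)cc1`: 14.5 h

In an ADME assay on the whole organism (plasma) for metabolic stability, with Gallus gallus as the target, with a stated time of 8 weeks (a lower number here means that the compound disappears faster, a higher number that the compound lasts longer), compound 3 gives the lowest number of the three, 14.5 h. Compound 1 at 38 h and compound 2 at 47 h both lie beyond the scatter from it.

Compound 4 `Cc1cc(-n2ncc(=O)[nH]c2=O)cc(Cl)c1S(=O)(=O)c1ccc(Cl)cc1` departs from compound 3 by a single change: chloro in place of hydrogen on an aromatic carbon. This is chloro in place of hydrogen on an aromatic carbon, ortho to a large group and meta to a methyl group.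

Among the compounds with values here, one measured step bears on this change: a 1.2-fold higher number from compound 1 to compound 2 (0.09 log units; within the scatter). It is the same replacement, and it stays within the scatter. It is thin support, since it is a single pair and compound 3 differs from compound 1 elsewhere in its structure. No step beyond the scatter is therefore expected in this assay, and any shift would more likely be slightly upward, as the sign of that one step suggests. The expected step is a 1.2-fold higher number from compound 3 to compound 4 (0.09 log units; within the scatter).

The estimated half-life of compound 4 is 18 h, with an expected range from 10 h to 32 h.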

Compound 4, half-life: 26 h
For compound 4 the middle estimate is 1.4-fold (0.16 log units) below the measured one, and the stated range covers the measured number.
By their numbers in this assay, from the lowest: compounds 3, 4, 1 and 2 (each within the scatter of the next, the first and the last beyond it).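

In this assay, chloro in place of hydrogen on an aromatic carbon, ortho to a large group and meta to a methyl group, gives a 1.8-fold higher number from compound 3 to compound 4 (0.25 log units; within the scatter). The replacement can now be read on two cores rather than one, and the two steps agree within the scatter: the same change on two cores in this assay, a 1.2-fold higher number (0.09 log units; within the scatter) from compound 1 to compound 2 and a 1.8-fold higher number (0.25 log units; within the scatter) from compound 3 to compound 4, 1.4-fold (0.16 log units) apart, within the scatter of two such steps. Within the data shown here, on these two pairs, then, the position takes a chloro without a shift that this read-out can separate from repeat scatter, on the core of compound 3 as on the core of compound 1, though two pairs support no rule beyond these compounds.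

What an amine, a carboxylic acid or a longer chain would do at this same position stays open, since chloro is the only group entering here among the compounds shown. Also open, from the compounds shown here alone, is whether the replacement stays within the scatter on cores other than these two.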